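Swapping an Aryl Group in a Weak Aortic Series

The source may hold more compounds than are shown below. What is called first, only, known or untested is meant among the compounds shown, and "the series" means these compounds.

Compound 3 `CCOc1nc(-c2nc3ccccc3n2C)cc(-c2ccc(Cl)cc2)c1C#N` gives 293000 nM in a functional assay on aorta (Rattus norvegicus, strain Wister) (a higher number here means a weaker inhibitor, a lower number a stronger inhibitor), the second highest of three numbers; compound 1 `COc1nc(-c2nc3ccccc3n2C)cc(-c2ccccc2)c1C#N` gives 300000 nM, within the scatter of compound 3, while compound 2 `COc1nc(-c2nc3ccccc3n2C)cc(-c2ccc(Cl)cc2)c1C#N` gives 145000 nM, and the step of a 2.0-fold higher number from compound 2 to compound 3 (0.31 log units; beyond the scatter) lies beyond it. Compound 4 `CCOc1nc(-c2nc3ccccc3n2C)cc(-c2cccs2)c1C#N` differs from compound 3 by thiophen-2-yl in place of 4-chlorophenyl on an aromatic carbon. Among the compounds with values here, no measured step exchanges one aromatic ring for another; the only change on that ring is a 2.1-fold lower number from compound 1 to compound 2 (0.32 log units; beyond the scatter), a modest step. Losing the chloro thus points to a somewhat higher number, and the thiophene has no precedent here. Compound 4 is therefore expected to give about 400000 nM in this assay, with a range of 150000 nM to 1000000 nM. The expected step of a 1.4-fold higher number from compound 3 to compound 4 (0.14 log units; within the scatter) is modest, and may fall within the scatter.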

Compound 4, half-maximal inhibitory concentration: 249000 nM
Beside the measured number, compound 4's estimate is 1.6-fold (0.21 log units) above it; low and high end bracket the measured number.
By their numbers in this assay, from the lowest: compounds 2, 4, 3 and 1 (each within the scatter of the next, the first and the last beyond it).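

Thiophen-2-yl in place of 4-chlorophenyl, on the aromatic carbon opposite the ring nitrogen, gives a 1.2-fold lower number from compound 3 to compound 4 (0.07 log units; within the scatter) in this assay. Within the data shown here, this is the first exchange of one whole aromatic ring for another, and it shows that this position accepts a five-membered ring with a sulfur without a change beyond the scatter. No available measurement bears on why the two rings read alike. On these data alone, whether an amine or a carboxylic acid on this ring would move the number remains open, as does whether thiophen-2-yl reads the same with a methoxy group in place of the ethoxy group.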